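The source may hold more compounds than are shown below. What is called first, only, known or untested is meant among the compounds shown, and "the series" means these compounds.

Measured so far:
compound 1 `Cc1cc(C)n(CCOC2CC(=O)Nc3c2c(C)nn3-c2ncnc3nc[nH]c23)n1` — 16 nM
compound 2 `Cc1nn(-c2ncnc3nc[nH]c23)c2c1C(NC(=O)Cc1cccs1)CC(=O)N2` — 3 nM

For the measured compounds named here, in a functional assay on HEK293 cells for agonist activity at G-protein coupled receptor 39 (Homo sapiens), read by scintillation proximity assay and inositol phosphate accumulation, with a stated time of 75 min, in the presence of a further agent that is not named here (on this read-out higher numbers stand for an effect only at larger amounts of compound and lower numbers for an effect already at smaller amounts), compound 2 stands at the lowest of the two numbers, with compound 1 the nearest, and the only measured step is a 5.3-fold lower number from compound 1 to compound 2 (0.73 log units; beyond the scatter).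

Compound 3 `Cc1nn(-c2ncnc3nc[nH]c23)c2c1C(OCCn1cccn1)CC(=O)N2` differs from compound 2 by 2-(1H-pyrazol-1-yl)ethoxy in place of (((thiophen-2-yl)methyl)carbonyl)amino on a saturated ring carbon. Going by the values given here, the only measured step bearing on this change is a 5.3-fold lower number from compound 1 to compound 2 (0.73 log units; beyond the scatter), which exchanged a group of the same kind as the one entering compound 3 for the group now leaving, and moved the number down. The change from compound 2 to compound 3 runs the other way, so the number for compound 3 is expected to rise back toward that of compound 1, with the difference in the two groups leaving room for some deviation. Compound 3 is therefore estimated at 20 nM in this assay, range 6 nM to 60 nM, an expected step of a 6.7-fold higher number from compound 2 to compound 3 (0.82 log units; beyond the scatter).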

Compound 3, half-maximal effective concentration: 16 nM
Compound 3: middle estimate off by 1.3-fold (0.10 log units), on the high side, and the stated range covers the measured number.
By their numbers in this assay, from the lowest: compound 2; then compounds 1 and 3 (each within the scatter of the next).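

In this assay, 2-(1H-pyrazol-1-yl)ethoxy on the saturated ring carbon gives a 5.3-fold higher number from compound 2 to compound 3 (0.73 log units; beyond the scatter), so the lower number of compound 2 is now seen against two ether-linked pyrazole side chains rather than one. The methyl groups of 3,5-dimethyl-1H-pyrazol-1-yl do not register on this read-out: their removal gives no change at the digits printed from compound 1 to compound 3 (within the scatter). The gap at this ring carbon therefore tracks the exchange with (((thiophen-2-yl)methyl)carbonyl)amino, not substitution on the pyrazole. Nothing shown accounts for either step.

The entering and leaving groups differ in both linkage and ring, and the compounds shown do not separate the amide link from the thiophene. Also open, as far as these compounds go, is how a phenylacetamide or a longer chain ending in pyrazole would read here.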